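Adding a second nitro group to compound 3

The source may report more compounds than this note shows. Statements on the series, on what has been measured and on what is new or still open speak of the compounds shown alone.

A cytotoxicity number tells how much of a compound living cells can tolerate. In an ADME assay on MT4 cells (Homo sapiens) for cytotoxicity, read by MTT assay, with a stated time of 96 h (a higher number here means that more compound is tolerated, a lower number that less compound is tolerated), compound 3 (`O=[N+]([O-])c1ccc(-c2nc3cc(C(F)(F)F)ccc3[nH]2)cc1`) gives 6000 nM and so sits in the low group of the three numbers available. In this assay compound 1 (`O=[N+]([O-])c1ccc(-c2nc3ccccc3[nH]2)c([N+](=O)[O-])c1`) gives 7000 nM and the two cannot be told apart, since their gap lies within the usual scatter. Compound 2 (`COc1ccc(-c2nc3cc(C(F)(F)F)ccc3[nH]2)c([N+](=O)[O-])c1`) stands clear of both at 85000 nM and that gap lies beyond the scatter.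

The next compound, compound 4 (`O=[N+]([O-])c1ccc(-c2nc3cc(C(F)(F)F)ccc3[nH]2)c([N+](=O)[O-])c1`), differs from compound 3 in one place: nitro in place of hydrogen on an aromatic carbon, ortho to a large group and meta to a nitro group. Among the compounds with values here, no measured pair in this small set shows that change on its own, so any expectation is indirect. Compound 1, which already carries two nitro groups, sits at 7000 nM and this points to no step beyond the scatter in this assay and no clear direction. The estimated step is a 1.1-fold higher number from compound 3 to compound 4 (0.03 log units; within the scatter) for now. The much higher number of compound 2 at 85000 nM keeps the range wide. Compound 4 is estimated at 6500 nM with 2000 nM to 20000 nM as its expected range.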

Compound 4, half-maximal cytotoxic concentration: 9000 nM
Compound 4: the middle estimate sits 1.4-fold (0.14 log units) below what was measured; the range from low to high includes it.
By their numbers in this assay, from the lowest: compounds 3, 1 and 4 (each within the scatter of the next); then compound 2.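

In this assay, a nitro group in place of hydrogen on this aromatic carbon, ortho to a large group and meta to a nitro group, gives a 1.5-fold higher number from compound 3 to compound 4 (0.18 log units; within the scatter), so this single change cannot be told apart from no change at all. Within the data shown here, the one clear step with compound 4 comes at a different carbon, where nitro in place of methoxy gives a 9.4-fold lower number from compound 2 to compound 4 (0.98 log units; beyond the scatter), while trifluoromethyl in place of hydrogen on the shared core gives a 1.3-fold higher number from compound 1 to compound 4 (0.11 log units; within the scatter) and so also stays inside the scatter. What sets these steps apart in size remains unexplained, as nothing measured here speaks to a reason.

Among these compounds, with only one new group tried on this carbon, it remains open whether the flat result belongs to this position in general or to nitro alone, and an amine, a carboxylic acid or a methoxy group at the same place could separate those two readings. Going by these compounds, it also remains open whether methoxy in place of hydrogen here would bring a step as large as the one seen with the methoxy of compound 2.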